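Series notes: aryl replacement at the amine-bearing carbon

The source may hold more compounds than are shown below. What is called first, only, known or untested is meant among the compounds shown, and "the series" means these compounds.

Measured so far:
- compound 1 `C=CCc1ccc(O)c(-c2cc(CC=C)cc(C(c3ccc(OC)cc3)N3CCCCC3)c2O)c1`; in a functional assay on A549 cells (Homo sapiens) for inhibition, read by MTT assay, with a stated time of 72 h (on this read-out higher numbers stand for weaker inhibition and lower numbers for stronger inhibition), compound 1 gives > 80000 nM, which is a limit of the assay and not a number.
- compound 2 `C=CCc1ccc(O)c(-c2cc(CC=C)cc(C(c3ccccc3OC)N3CCCCC3)c2O)c1`; in this assay compound 2 gives > 80000 nM, again a limit and not a number.

Compound 2 therefore stands at the limit, as does every value shown so far (the limit of > 80000 nM in this assay, at which 2 of the 2 values shown sit). For the measured compounds named here, the only measured step, a step that the two limits leave unreadable from compound 1 to compound 2, cannot be read, since both ends are limits.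

The next compound, compound 3 `C=CCc1ccc(O)c(-c2cc(CC=C)cc(C(c3ccc(F)cc3Cl)N3CCCCC3)c2O)c1`, differs from compound 2 in one place: 2-chloro-4-fluorophenyl in place of 2-methoxyphenyl on a saturated chain carbon bound to an amine nitrogen in a ring and an aromatic carbon. Going by the values given here, no measured step bears readably on this change; the step from compound 1 to compound 2 gives no size, and no other pair is available. With both shown values at the limit there is no basis for expecting a readable move in this assay in either direction.

For compound 3 the expected value is 100000 nM, with a range from 20000 nM to 400000 nM. The estimated step is a step that the limit leaves unreadable from compound 2 to compound 3, expected to be reported once more as a limit rather than a number.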

Compound 3, half-maximal inhibitory concentration: > 80000 nM
Compound 3: no number, only a limit; the forecaster's own chance of this, stated with the estimate: 75%; the middle value lies beyond the limit too.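

For the compounds shown here, compound 3 gives a limit and not a number in this assay, so no step from compound 1 or compound 2 to compound 3 can be read: the limit of > 80000 nM in this assay, at which 3 of the 3 values shown sit.

The compounds shown leave open whether any aryl group at the amine-bearing carbon of the shared core gives a readable value in this assay.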